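A Thiosemicarbazone Series Loses Its Phenol

The source may report more compounds than this note shows. Statements on the series, on what has been measured and on what is new or still open speak of the compounds shown alone.

compound 1, `CC1=CC[C@@H]([C@@](C)(O)CCCC(C)(C)NC(=S)N/N=C\c2ccc(O)cc2)CC1`: 6070 nM
compound 2, `CC1=CC[C@@H]([C@@](C)(O)CCCC(C)(C)NC(=S)N/N=C\c2ccc(N(C)C)cc2)CC1`: > 100000 nM (a limit)
compound 3, `CC1=CC[C@@H]([C@@](C)(O)CCCC(C)(C)NC(=S)N/N=C\c2ccccc2[N+](=O)[O-])CC1`: > 100000 nM (a limit)

Going by the values given here, in a functional assay on NCI/ADR cells (Homo sapiens) for cytotoxicity, read by sulforhodamine B assay (a higher number here means a weaker inhibitor of growth, a lower number a stronger inhibitor of growth), compound 1 gives 6070 nM, the only number among the three. For compound 2 the assay reports only a limit, > 100000 nM. For compound 3 likewise only a limit is reported, > 100000 nM. The two measured steps, an at least 16-fold higher number from compound 1 to compound 2 (1.21 log units; beyond the scatter) and an at least 16-fold higher number from compound 1 to compound 3 (1.21 log units; beyond the scatter), both end at the limit of > 100000 nM in this assay, at which 2 of the 3 values shown sit. Compound 4, `CC1=CC[C@@H]([C@@](C)(O)CCCC(C)(C)NC(=S)N/N=C(/C)c2ccccc2)CC1`, differs from compound 1 by a group of 9 heavy atoms (8 carbon, 1 nitrogen; one six-membered aromatic ring of carbon only) in place of a group of 9 heavy atoms (7 carbon, 1 nitrogen, 1 oxygen; one six-membered aromatic ring of carbon only), on an amide-type nitrogen. Both measured departures from the hydroxyphenyl of compound 1 were large, so a large weakening is expected here too. Compound 4 is therefore estimated at 60000 nM, within 15000 nM to 150000 nM. That estimate means an expected step of a 9.9-fold higher number from compound 1 to compound 4 (0.99 log units; beyond the scatter).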

Compound 4, concentration for total growth inhibition: > 100000 nM
Compound 4 ended at the assay's limit (the forecaster's own chance of this, stated with the estimate: 55%); middle value at least 1.6-fold (0.22 log units) away from the limit.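

In this assay, swapping the hydroxyphenyl group gives an at least 16-fold higher number from compound 1 to compound 4 (1.21 log units; beyond the scatter), so a third departure, this one carrying neither dimethylamino nor nitro, also ends far from the value of the phenol. Going by these compounds alone, the value of compound 4 is a limit, and compound 1 remains the only compound with a readable number: the limit of > 100000 nM in this assay, at which 3 of the 4 values shown sit. Steps among compound 2, compound 3 and compound 4 cannot be read.

Compound 4 also differs by a methyl on the carbon with a double bond to nitrogen, so these compounds do not separate that methyl from the loss of the hydroxy. Going by these compounds, whether a methoxy or an amino group in place of the hydroxy would retain growth inhibition stays open.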